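Cyclohexyl in place of 4-methylbenzyl on a shared core

The source may hold more compounds than are shown below. What is called first, only, known or untested is meant among the compounds shown, and "the series" means these compounds.

Of the compounds shown here, three sharing one core have been measured in a functional assay on RAW264.7 cells (Mus musculus) for inhibition, read by Griess assay, with stated times of 2 h and 24 h; a lower number here means a stronger inhibitor, a higher number a weaker inhibitor. Compound 1 (`COc1ccc([C@@H]2CC(=O)c3c(O)cc(OCc4cn(C5CCCC5)nn4)cc3O2)cc1O`), with cyclopentyl on an aromatic nitrogen, gives 10500 nM. Compound 2 (`COc1ccc([C@@H]2CC(=O)c3c(O)cc(OCc4cn(Cc5ccccc5C#N)nn4)cc3O2)cc1O`), with 2-cyanobenzyl at that place, gives 14600 nM. Compound 3 (`COc1ccc([C@@H]2CC(=O)c3c(O)cc(OCc4cn(Cc5ccc(C)cc5)nn4)cc3O2)cc1O`), with 4-methylbenzyl there, gives 16800 nM. On these numbers compound 3 cannot be separated from the other two: the data show a 1.2-fold higher number from compound 2 to compound 3 (0.06 log units; within the scatter) and a 1.6-fold higher number from compound 1 to compound 3 (0.20 log units; within the scatter), and both steps lie within the scatter. The remaining step, a 1.4-fold higher number from compound 1 to compound 2 (0.14 log units; within the scatter), lies within it as well.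

Compound 4 (`COc1ccc([C@@H]2CC(=O)c3c(O)cc(OCc4cn(C5CCCCC5)nn4)cc3O2)cc1O`) has not yet been measured. It carries cyclohexyl in place of 4-methylbenzyl on an aromatic nitrogen of a five-membered aromatic ring with 3 nitrogen: cyclohexyl in place of 4-methylbenzyl on an aromatic nitrogen. Among the measured compounds shown here, no measured step makes this exact exchange. The closest one links cyclopentyl in compound 1 to 4-methylbenzyl in compound 3, a 1.6-fold higher number from compound 1 to compound 3 (0.20 log units; within the scatter), read here in reverse. For the measured compounds named here, with every step so far inside the scatter, no step beyond the scatter is expected in this assay. The estimate amounts to an expected 1.4-fold lower number from compound 3 to compound 4 (0.15 log units; within the scatter). For compound 4 the expected value is 12000 nM, with an estimated range from 6000 nM to 24000 nM.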

Compound 4, half-maximal inhibitory concentration: 15600 nM
Compound 4: the middle estimate sits 1.3-fold (0.11 log units) below what was measured; low and high end bracket the measured number.
By their numbers in this assay, from the lowest: compounds 1, 2, 4 and 3 (each within the scatter of the next).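

In this assay, the exchange of 4-methylbenzyl, with its six-membered aromatic ring, for cyclohexyl, with its smaller non-aromatic ring of carbon only, gives a 1.1-fold lower number from compound 3 to compound 4 (0.03 log units; within the scatter) and so does not separate the two compounds. The other benzyl group behaves alike: replacing 2-cyanobenzyl with cyclohexyl gives a 1.1-fold higher number from compound 2 to compound 4 (0.03 log units; within the scatter) and cyclohexyl in place of cyclopentyl gives a 1.5-fold higher number from compound 1 to compound 4 (0.17 log units; within the scatter) on the same aromatic nitrogen, so neither a benzyl group nor an aromatic ring is needed here for a number in this range, and the four compounds cannot be told apart. Nothing available explains why these exchanges on the aromatic nitrogen leave the number within the scatter.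

The compounds shown leave open whether any group on this nitrogen can move the number beyond the scatter, for instance a carboxylic acid or a primary amine on the benzyl ring, or a longer straight alkyl chain. They also leave open whether a stronger inhibitor can come from this position at all or only from a change elsewhere on the shared core.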